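From oxolan-3-yl to oxan-4-yl on the shared core

This account rests on a few compounds, and the source may have more. Where it says the series, first, only, none or still open, it means among the compounds named here.

Within the data shown here, in a physicochemical assay for solubility, using the shake flask method, in phosphate buffer, measured as kinetic solubility, with a stated time of 20 h, at pH 6.5 (on this read-out lower numbers stand for lower solubility and higher numbers for higher solubility), compound 3 `FC(F)(F)c1ccc(Nc2cc3[nH]c(C4CCOC4)nc3cn2)nc1` gives 166000 nM as the only actual number so far. Compound 1 `FC(F)(F)c1ccc(Nc2cc3[nH]c(-c4cccc(C(F)(F)F)c4)nc3cn2)nc1` stands at < 5000 nM as a limit of the assay. Compound 2 `Fc1ccc(-c2nc3cnc(Nc4ccc(C(F)(F)F)cn4)cc3[nH]2)cc1F` stands at < 5000 nM as a limit too. Compound 4 `FC(F)(F)c1ccc(Nc2cc3[nH]c(C4CCOCC4)nc3cn2)nc1` is unmeasured, and the change is oxan-4-yl in place of oxolan-3-yl on an aromatic carbon on an aromatic carbon. Two large steps bear on it: an at least 33-fold higher number from compound 1 to compound 3 (1.52 log units; beyond the scatter) and an at least 33-fold higher number from compound 2 to compound 3 (1.52 log units; beyond the scatter) each put oxolan-3-yl in place of an aryl group. Neither exchanges one non-aromatic ring for another, so neither sets a size for this change. The expectation in this assay is no step beyond the scatter, with any drift towards lower numbers. The estimated step is a 1.4-fold lower number from compound 3 to compound 4 (0.14 log units; within the scatter) for now. The estimate for compound 4 is 120000 nM with an expected range of 40000 nM to 300000 nM in this series.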

Compound 4, solubility: 155000 nM
Compound 4: middle estimate off by 1.3-fold (0.11 log units), on the low side; the range from low to high includes it.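

In this assay the exchange of one non-aromatic ring for another gives a 1.1-fold lower number from compound 3 to compound 4 (0.03 log units; within the scatter) and so no separation between oxolan-3-yl and oxan-4-yl at this position. The aryl comparisons give an at least 31-fold higher number from compound 2 to compound 4 (1.49 log units; beyond the scatter) and an at least 31-fold higher number from compound 1 to compound 4 (1.49 log units; beyond the scatter) so the large step now holds for two non-aromatic rings, not one. Compound 1 and compound 2 each stand at a limit and not a number: the limit of < 5000 nM in this assay, at which 2 of the 4 values shown sit.

Open, as far as these compounds go, is how an amine, a carboxylic acid or a longer chain in place of oxan-4-yl would read at this position. From the compounds shown here alone, the true size of both aryl steps also stays open.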